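The source may report more compounds than this note shows. Statements on the series, on what has been measured and on what is new or still open speak of the compounds shown alone.

Measured so far in a physicochemical assay for metabolic stability, read by HPLC, at pH 4.5, tested at 10 uM; a higher number here means that the compound lasts longer, a lower number that the compound disappears faster:

Compound 1, `CCCCCCNC(=O)N1C(=O)c2ccccc2C1=O`, gives > 2 h, which is a limit of the assay rather than a number.
Compound 2, `COc1nc2ccccc2n1C(=O)NCCCCc1ccccc1`, gives > 2 h, again a limit rather than a number.
Compound 3, `Cc1nc2ccccc2n1C(=O)NCCCCc1ccccc1`, gives 0.133 h.

Among the measured compounds shown here, compound 3 therefore stands as the only real number among the three; the other two sit at the limit of > 2 h in this assay, at which 2 of the 3 values shown sit. For the measured compounds named here, the single measured step that changes one place is an at least 15-fold lower number from compound 2 to compound 3 (1.17 log units; beyond the scatter), a large drop that goes well beyond the usual scatter.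

Compound 4, `Nc1nc2ccccc2n1C(=O)NCCCCc1ccccc1`, is the next compound to be tested. Relative to compound 3 the change is amino in place of methyl on an aromatic carbon. Going by the values given here, only one measured step bears on this: it swapped the group at this same carbon of the shared core, with methyl in place of methoxy, and that swap lowered the value sharply, as an at least 15-fold lower number from compound 2 to compound 3 (1.17 log units; beyond the scatter) shows. Among the compounds with values here, compound 4 moves away from methyl again, to amino, so the expectation is that the number rises, though by how much cannot be read from a single step, and the amino group itself has no precedent here.

On that basis the half-life of compound 4 is estimated at 1.2 h, with a plausible range from 0.3 h to 4 h, an expected step of a 9.0-fold higher number from compound 3 to compound 4 (0.96 log units; beyond the scatter).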

Compound 4, half-life: 0.717 h
For compound 4 the middle estimate is 1.7-fold (0.22 log units) above the measured one; the measured number falls inside the stated range.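

In this assay, among the compounds shown here, this second swap on the aromatic carbon between two ring nitrogen atoms again moves the half-life beyond the scatter: amino in place of methyl gives a 5.4-fold higher number from compound 3 to compound 4 (0.73 log units; beyond the scatter), so the earlier drop was not peculiar to the single change from methoxy to methyl. Amino does not, however, restore the full stability seen with methoxy, since amino in place of methoxy gives an at least 2.7-fold lower number from compound 2 to compound 4 (0.44 log units; beyond the scatter), and the three groups at this one carbon now fall in the order methoxy, amino, methyl, from longest to shortest half-life. That last step can be stated only as a minimum, because the value of compound 2 is a limit of the assay and not a number: the limit of > 2 h in this assay, at which 2 of the 4 values shown sit.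

The compounds shown do not tell why these three groups differ, or how far compound 2 actually lies from compound 4. Where a hydroxyl group, a dimethylamino group or an ethyl group at this same carbon would fall in the order also remains open, as does whether the order would hold with a shorter chain on the shared core.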